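The compounds below may be only part of what the source reports. "The series", "measured", "known", "first", "only" and "open" are said of these compounds alone.

Of the compounds shown here, three have been tested in a toxicity assay on MT4 cells (Homo sapiens) for cytotoxicity, read by MTT assay, with a stated time of 5 days; a lower number here means that less compound is tolerated, a higher number that more compound is tolerated. Compound 1 `Cc1cnc(Nc2ccc(C#N)cc2)nc1Nc1c(F)cc(-c2cncc(C(F)(F)F)c2)cc1F` gives 8200 nM in this assay, compound 2 `Cc1cnc(Nc2ccc(C#N)cc2)nc1Nc1c(F)cc(-c2cncc(C#N)c2)cc1F` gives 50000 nM, and compound 3 `Cc1cc(-c2cnc(C#N)nc2)cc(C)c1Nc1ccnc(Nc2ccc(C#N)cc2)n1` gives 3100 nM. Compound 3 has the lowest number of the three; compound 1 stands nearest to it and compound 2 furthest away, both gaps beyond the scatter. Compound 1 and compound 2 differ in a single place: trifluoromethyl in place of cyano on an aromatic carbon That change made a 6.1-fold lower number from compound 2 to compound 1 (0.79 log units; beyond the scatter), meaning that less compound was tolerated after it.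

Compound 4 `Cc1cc(-c2cnc(C(F)(F)F)nc2)cc(C)c1Nc1ccnc(Nc2ccc(C#N)cc2)n1` has not yet been measured. It arises from compound 3 by the same kind of change: trifluoromethyl in place of cyano on an aromatic carbon The cores of compound 2 and compound 3 are not the same, and the difference between them is not broken down here. The surroundings of the change also differ: in compound 1 the group sits on a six-membered aromatic ring with 1 nitrogen, two atoms from the ring nitrogen and meta to a large group, while in compound 4 it sits on a six-membered aromatic ring with 2 nitrogen, between two ring nitrogen atoms and para to a large group. Because the earlier change made a 6.1-fold lower number from compound 2 to compound 1 (0.79 log units; beyond the scatter), a step in the same direction is expected here, somewhat smaller as the ring around the place differs, estimated as a 4.4-fold lower number from compound 3 to compound 4 (0.65 log units; beyond the scatter). Compound 4 is therefore expected to give about 700 nM in this assay, most likely between 250 nM and 2000 nM.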

Compound 4, half-maximal cytotoxic concentration: 4900 nM
The estimate for compound 4 lay 7.0-fold (0.85 log units) below the measured number; the measured number lies above the stated range.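

In this assay, putting trifluoromethyl in place of cyano on the ring with 2 nitrogen gave a 1.6-fold higher number from compound 3 to compound 4 (0.20 log units; within the scatter), so on this core the swap produced no difference that can be separated from the ordinary spread of repeat measurements. The effect of this swap therefore did not carry over from one core to the other, and a step seen on one core was a poor guide to the step on the next: the same change on two cores in this assay, a 6.1-fold lower number (0.79 log units; beyond the scatter) from compound 2 to compound 1 and a 1.6-fold higher number (0.20 log units; within the scatter) from compound 3 to compound 4, 9.6-fold (0.98 log units) apart, beyond the scatter of two such steps. This does not show why the two steps differ, since the two pairs differ both in their cores and in the ring that carries the group, with 1 nitrogen in one pair and 2 nitrogen in the other, and two pairs cannot separate these differences or establish a rule for the series.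

As far as these compounds go, it remains open whether the swap would behave the same way if only the ring carrying the group varied while the rest of the core stayed fixed. From the compounds shown here alone, it is also open how other groups at this place, such as a chlorine atom, an amine or a carboxylic acid, would fare in this assay.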